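A few compounds are considered here, and "the series" means these few. Any claim that something is new, unique, unknown or untested is made for them only; others in the source may bear on it.

Compound 2, whose structure is `COc1cc(-c2nn(-c3cccc(NC(=O)c4ccc(Cl)c(C(F)(F)F)c4)c3)cc2-c2ccncc2)ccc1Cl`, gives 13100 nM in a functional assay on HOP-62 cells (Homo sapiens) for inhibition, read by sulforhodamine B assay, with a stated time of 48 h; a lower number here means a stronger inhibitor of growth, a higher number a weaker inhibitor of growth. Among the three measured compounds it has the highest number, which here means the weakest inhibition of growth. Compound 1, with structure `O=C(Nc1cccc(-n2cc(-c3ccncc3)c(-c3ccc(Cl)c(O)c3)n2)c1)Nc1ccc(Cl)c(Cl)c1`, gives 2080 nM in this assay, and compound 3, with structure `O=C(Nc1cccc(-n2cc(-c3ccncc3)c(-c3ccc(Cl)c(O)c3)n2)c1)Nc1cc(C(F)(F)F)cc(C(F)(F)F)c1`, gives 964 nM; both of these gaps to compound 2 lie beyond the usual scatter. Compounds 1 and 3 share a urea linkage to their outer aryl group, whereas compound 2 carries a plain amide there.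

Compound 4, with structure `COc1cc(-c2nn(-c3cccc(NC(=O)Nc4cccc(C(F)(F)F)c4)c3)cc2-c2ccncc2)ccc1Cl`, is not yet measured. Relative to compound 2 it differs in one place: (3-(trifluoromethyl)phenyl)amino in place of 4-chloro-3-(trifluoromethyl)phenyl on a carbonyl carbon. This converts the amide of compound 2 into a urea like those seen in compounds 1 and 3, although the methoxy-bearing aryl of compound 2 is kept. For the measured compounds named here, since no measured pair isolates this exact change, the expectation rests on the comparison above.

The step from compound 2 to compound 4 in this assay is expected to be a lowering of the number, by a 3.3-fold lower number from compound 2 to compound 4 (0.52 log units; beyond the scatter), beyond the scatter. Compound 4 is therefore estimated at 4000 nM, within a range from 1500 nM to 12000 nM.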

Compound 4, concentration for 50% growth inhibition: 1340 nM
Beside the measured number, compound 4's estimate is 3.0-fold (0.47 log units) above it; the whole stated range lies above it.
By their numbers in this assay, from the lowest: compounds 3, 4 and 1 (each within the scatter of the next, the first and the last beyond it); then compound 2.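

In this assay, for the compounds shown here, the swap gives a 9.8-fold lower number from compound 2 to compound 4 (0.99 log units; beyond the scatter) and so shows that this place on the carbonyl carbon responds to a single change, something the earlier compounds, which offered no one-place pair, could not show. The change does two things at once: it adds an amino nitrogen, carrying a hydrogen-bond donor, and it removes the chlorine, so this step alone cannot divide the gain between them. Nothing measured here explains the gain.

Still open, as far as these compounds go, is how (4-chloro-3-(trifluoromethyl)phenyl)amino would compare on this carbonyl carbon, since that group would keep the chlorine together with the amino nitrogen. Also open, from the compounds shown here alone, is how a methylamino link, with a methyl group on that nitrogen, would behave at the same place.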